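Cyclic sulfonamide replacing a cyclic urea on the piperidine carbon

A few compounds are considered here, and "the series" means these few. Any claim that something is new, unique, unknown or untested is made for them only; others in the source may bear on it.

Compound 1 `COCC(=O)NC1CCN(c2nc(C)c3cc(NC(=O)/C=C/c4ccc(OC(F)(F)F)cc4)ccc3n2)CC1`: 57%
Compound 2 `Cc1nc(N2CCC(N3CCNC3=O)CC2)nc2ccc(NC(=O)/C=C/c3ccc(OC(F)(F)F)cc3)cc12`: 89%

In an ADME assay on microsomes from liver (Mus musculus) for metabolic stability, with a stated time of 30 min (on this read-out higher numbers stand for a more stable compound and lower numbers for a less stable compound), compound 2 gives 89%, the higher of the two numbers; its nearest measured neighbour is compound 1, which in this assay gives 57%, and the step of a number 32 percentage points higher from compound 1 to compound 2 (beyond the scatter) lies beyond the scatter. Compound 3 `Cc1nc(N2CCC(N3CCCS3(=O)=O)CC2)nc2ccc(NC(=O)/C=C/c3ccc(OC(F)(F)F)cc3)cc12` has not yet been measured. It differs from compound 2 in one place: a group of 7 heavy atoms (3 carbon, 1 nitrogen, 2 oxygen, 1 sulfur; one five-membered non-aromatic ring with 2 hetero atoms) in place of a group of 6 heavy atoms (3 carbon, 2 nitrogen, 1 oxygen; one five-membered non-aromatic ring with 2 hetero atoms), on a saturated ring carbon, three ring bonds from the ring nitrogen of the six-membered non-aromatic ring. Among the measured compounds shown here, the only measured step exchanges a group on the same ring carbon, but neither of its groups is the one that enters here, so it does not bear directly on this change. For the measured compounds named here, with no measured step showing the entering group, no change beyond the scatter is expected, and the step of a number 9 percentage points lower from compound 2 to compound 3 (within the scatter) is estimated as small, if anything slightly downward. Compound 3 is therefore expected to give about 80%, within 60% to 95%.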

Compound 3, percent of the compound remaining: 83%
Compound 3: middle estimate off by 3 percentage points, on the low side; the range from low to high includes it.
By their numbers in this assay, from the lowest: compound 1; then compounds 3 and 2 (each within the scatter of the next).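

In this assay, the sulfur-containing five-membered ring on the saturated ring carbon takes the place of 2-oxoimidazolidin-1-yl with a number 6 percentage points lower from compound 2 to compound 3 (within the scatter), so this position accepts a second cyclic group with no change that can be told from the scatter. Set against the open-chain ((methoxymethyl)carbonyl)amino group, the same ring gives a number 26 percentage points higher from compound 1 to compound 3 (beyond the scatter), which puts both five-membered rings shown beyond the scatter above that open-chain group. No measurement at hand accounts for these numbers.

As far as these compounds go, what remains open is whether the ring itself matters or only the atoms it carries, which an open-chain methylsulfonylamino group on the same carbon would help to separate. From the compounds shown here alone, how a six-membered cyclic urea or a plain amine would fare at this position also remains unknown.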